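A few compounds are considered here, and "the series" means these few. Any claim that something is new, unique, unknown or untested is made for them only; others in the source may bear on it.

Measured in a functional assay on WiDr cells (Homo sapiens) for inhibition, read by sulforhodamine B assay, with a stated time of 48 h; a lower number here means a stronger inhibitor of growth, a higher number a weaker inhibitor of growth:
- compound 1 `O=C(CCC(F)(F)C(F)(F)C(F)(F)C(F)(F)F)NCCCCCCCCCN[C@@H]1[C@H](O)[C@@H](O)[C@H](O)[C@H]2COC(=O)N21`: > 100000 nM
- compound 2 `O=C(CCC(F)(F)C(F)(F)C(F)(F)C(F)(F)C(F)(F)C(F)(F)F)NCCCCCCCCCN[C@@H]1[C@H](O)[C@@H](O)[C@H](O)[C@H]2COC(=O)N21`: 13000 nM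
- compound 3 `O=C(CCC(F)(F)C(F)(F)C(F)(F)C(F)(F)F)NCCCCCCCCCN[C@@H]1[C@H](O)[C@@H](O)[C@@H](O)[C@H]2COC(=O)N21`: > 100000 nM

Compound 3 stands at > 100000 nM, which is a limit and not a number. Compound 1 at > 100000 nM is likewise a limit.

Compound 4 `O=C(CCC(F)(F)C(F)(F)C(F)(F)C(F)(F)C(F)(F)C(F)(F)F)NCCCCCCCCCN[C@@H]1[C@H](O)[C@@H](O)[C@@H](O)[C@H]2COC(=O)N21` differs from compound 3 by 1,1,2,2,2-pentafluoroethyl in place of fluoro on a saturated chain carbon bound to two fluorine atoms and a saturated chain carbon: 1,1,2,2,2-pentafluoroethyl in place of fluoro. The same change gave an at least 7.6-fold lower number from compound 1 to compound 2 (0.88 log units; beyond the scatter). Carrying it over rests on (the fact that compounds 1 and 3 differ only in the configuration as drawn), and the only direct comparison is a step that the two limits leave unreadable from compound 1 to compound 3.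

A lower number is therefore expected in this assay, of a size similar to that step or larger. The estimated step is an at least 6.6-fold lower number from compound 3 to compound 4 (0.82 log units; beyond the scatter). Compound 4 is expected at 15000 nM, with an estimated range of 5000 nM to 60000 nM.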

Compound 4, concentration for 50% growth inhibition: 17000 nM
Compound 4: middle estimate off by 1.1-fold (0.05 log units), on the low side; measured number inside the range.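

In this assay, 1,1,2,2,2-pentafluoroethyl in place of fluoro also registers on the other configuration, with an at least 5.8-fold lower number from compound 3 to compound 4 (0.76 log units; beyond the scatter). Compound 3 at > 100000 nM is a limit, so this step is a bound. The configuration at the saturated ring carbon, unreadable for the shorter pair, can now be read for the longer pair, with a 1.3-fold higher number from compound 2 to compound 4 (0.12 log units; within the scatter).

Going by these compounds, whether the size of the change differs between the two configurations stays open. Also open, on these data alone, is whether an amine, a carboxylic acid or a longer perfluoroalkyl chain in place of 1,1,2,2,3,3,3-heptafluoropropyl would keep this activity.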